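Moving from a methyl to a chlorine on the aryl ring

The compounds below may be only part of what the source reports. "The series", "measured", "known", "first", "only" and "open" are said of these compounds alone.

Of the compounds shown here, three of one series have been measured in a functional assay on HEK293 cells with D(4) dopamine receptor (Homo sapiens) as the target, read by FLIPR; a lower number here means that less compound is needed, a higher number that more compound is needed for the effect. Compound 1, with structure `O/N=C(/CCN1CCN(c2ccccn2)CC1)c1ccccc1Cl`, gives 25 nM. Compound 2, `Cc1ccccc1/C(CCN1CCN(c2ccccn2)CC1)=N/O`, gives 4.2 nM. Compound 3, `Cc1cccc(/C(CCN2CCN(c3ccccn3)CC2)=N/O)c1`, gives 2.3 nM. Compound 2 thus stands second highest of the three numbers, nearest to compound 3 and furthest from compound 1. The one step within this set, a 1.8-fold lower number from compound 2 to compound 3 (0.26 log units; within the scatter), moves the methyl group around the ring and stays within the scatter, so the position of a small group on that ring has not yet shown a clear effect. Compound 4, `O/N=C(\CCN1CCN(c2ccccn2)CC1)c1ccc(Cl)cc1`, is the next step from compound 2: 4-chlorophenyl in place of 2-methylphenyl on a carbon with a double bond to nitrogen. Among the compounds with values here, no measured step exchanges a methyl for a chlorine in this way, so the expectation rests on the spread of the values seen so far. Compound 4 is therefore estimated at 10 nM, with a range from 3 nM to 40 nM, which corresponds to an expected step of a 2.4-fold higher number from compound 2 to compound 4 (0.38 log units; beyond the scatter).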

Compound 4, half-maximal effective concentration: 475 nM
Compound 4: middle estimate off by 48-fold (1.68 log units), on the low side; measured number above the stated range.
By their numbers in this assay, from the lowest: compounds 3 and 2 (each within the scatter of the next); then compound 1; then compound 4.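

In this assay the change to 4-chlorophenyl brings a 110-fold higher number from compound 2 to compound 4 (2.05 log units; beyond the scatter) and also a 210-fold higher number from compound 3 to compound 4 (2.31 log units; beyond the scatter) and so shows that this carbon's aryl group can strongly shift the number, although moving the methyl had left it within the scatter. The 2-methylphenyl and 4-chlorophenyl groups have the same heavy-atom count, so a matching count does not ensure a similar result at this place. No measurement shown here accounts for the size of this rise.

The step alters both the group on the ring and its place on the ring, leaving open which of the two matters, a question that a 4-methylphenyl group at this carbon could address. On these data alone, how a 4-methoxyphenyl or 4-aminophenyl group would behave here also remains open.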